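Cytotoxicity Notes: Fluoro to Methyl on the Phenyl Ring

A few compounds are considered here, and "the series" means these few. Any claim that something is new, unique, unknown or untested is made for them only; others in the source may bear on it.

Three members of the series have been tested in an ADME assay on Vero cells (Chlorocebus sabaeus) for cytotoxicity, read by resazurin assay, with a stated time of 3 days; a lower number here means a stronger inhibitor, a higher number a weaker inhibitor. Compound 1 `CCN(CC)c1cc2[nH]c(C3CCCCC3)nc2cc1NC(=O)c1ccc(F)cc1` reaches only the limit of the assay, reported as > 100 ug/mL. Compound 2 `CCCCOC(=O)Nc1cc2nc(C3CCCCC3)[nH]c2cc1N(CCC)CCC` likewise stops at a limit, > 100 ug/mL. Compound 3 `CCCc1ccc(C(=O)Nc2cc3nc(C4CCCCC4)[nH]c3cc2N(C)C)cc1` also gives no number but a limit, > 100 ug/mL. Among the compounds with values here, compound 1 thus stands where every measured value of the series stands, namely at the limit of > 100 ug/mL in this assay, at which 3 of the 3 values shown sit, and no measured step between two numbers exists from which a size could be read.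

Compound 4 `CCN(CC)c1cc2[nH]c(C3CCCCC3)nc2cc1NC(=O)c1ccc(C)cc1` differs from compound 1 in one place: methyl in place of fluoro on an aromatic carbon. With every value at the limit, no step beyond the scatter is expected in this assay in either direction, and the expected step is a number no higher from compound 1 to compound 4 (the limit leaves the size open). Compound 4 is therefore expected to come out at about 100 ug/mL, within a range from 50 ug/mL to 200 ug/mL, most likely again reported as a limit rather than a number.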

Compound 4, half-maximal inhibitory concentration: > 100 ug/mL
Compound 4 ended at the assay's limit; the forecaster's own chance of this, stated with the estimate: 85%; the middle value sits exactly at the limit.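

No step can be read from compound 1 to compound 4 in this assay: both results are limits, not numbers. The compounds shown leave open whether methyl in place of fluoro changes cytotoxicity at all, and how far any compound lies beyond the limit: the limit of > 100 ug/mL in this assay, at which 4 of the 4 values shown sit.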